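The compounds below may be only part of what the source reports. "The series", "measured", "known", "first", "only" and "open" are said of these compounds alone.

Compound 1 `CS(=O)(=O)c1ccc(Nc2ncc(F)c(Nc3nc4ccccc4s3)n2)cc1` gives 2830 nM in a functional assay on PC-3 cells (Homo sapiens) for antiproliferative activity, read by MTT assay, with a stated time of 48 h; a lower number here means a stronger inhibitor, a higher number a weaker inhibitor. Compound 2 `Cc1cnc(Nc2ccc(C(C)C)cc2)nc1Nc1nc2ccccc2s1` reaches only the limit of this assay, > 50000 nM, which is a limit rather than a measured number (the limit of > 50000 nM in this assay, at which 1 of the 2 values shown sits). Compound 3 `Cc1cnc(Nc2ccc(S(C)(=O)=O)cc2)nc1Nc1nc2ccccc2s1` differs from compound 2 by methylsulfonyl in place of isopropyl on an aromatic carbon. Compound 1 carries the same methylsulfonyl group and gives 2830 nM. A large gain in potency is therefore expected for compound 3, with a step of an at least 10-fold lower number from compound 2 to compound 3 (1.00 log units; beyond the scatter). The estimated value for compound 3 in this assay is 5000 nM, expected to fall between 1500 nM and 20000 nM.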

Compound 3, half-maximal inhibitory concentration: > 50000 nM
Compound 3: only a limit was reported; the forecaster's own chance of this, stated with the estimate: 20%; middle value at least 10-fold (1.00 log units) from the limit.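

Methylsulfonyl in place of isopropyl does not by itself bring measurable activity in this assay, and the step between compound 2 and compound 3 cannot be read. Compound 2 and compound 3 both stand at a limit, not at a number: the limit of > 50000 nM in this assay, at which 2 of the 3 values shown sit. Among these compounds, the single change of methyl in place of fluoro on an aromatic carbon gives an at least 17-fold higher number from compound 1 to compound 3 (1.24 log units; beyond the scatter), so this place on the core matters strongly with methylsulfonyl present.

The compounds shown leave open whether fluoro would also bring the isopropyl compound into measurable range. From the compounds shown here alone, how chloro or an amine would read at that place also stays open.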